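Swapping the carboxyphenyl substituent in a pair of linked benzophenone-type ethers

The source may hold more compounds than are shown below. What is called first, only, known or untested is meant among the compounds shown, and "the series" means these compounds.

Measured compounds:
compound 1 `COC(=O)c1ccc(OCCCCOc2ccc(C(=O)CC3CCCC3)c(O)c2C)cc1` — "not determined" (no result reported)
compound 2 `Cc1c(OCCCCOc2ccc(C(=O)O)c(Cl)c2)ccc(C(=O)CC2CCCC2)c1O` — 510 nM

In an assay on HEK293 cells for positive allosteric modulation of metabotropic glutamate receptor 2 (Rattus norvegicus), read by thallium flux, with a stated time of 2.5 min (on this read-out higher numbers stand for an effect only at larger amounts of compound and lower numbers for an effect already at smaller amounts), compound 2 gives 510 nM. For compound 1 the entry in this assay reads "not determined" (no result reported), so no number stands beside it. Among the measured compounds shown here, compound 2 therefore holds the only value in this assay; there is nothing to rank it against.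

Compound 3 `Cc1cc(C(=O)O)ccc1OCCCCOc1ccc(C(=O)CC2CCCC2)c(O)c1C` differs from compound 2 in one place: 4-carboxy-2-methylphenyl in place of 4-carboxy-3-chlorophenyl on an oxygen on a saturated carbon. For the measured compounds named here, no measured pair shows how such a swap plays out here. With one value and one comparison that has no measured partner, the step from compound 2 to compound 3 is expected to be small, in either direction, and probably not beyond the scatter of this assay. Compound 3 is therefore expected to land near 600 nM, within a range from 200 nM to 1800 nM, meaning an expected step of a 1.2-fold higher number from compound 2 to compound 3 (0.07 log units; within the scatter) in this assay.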

Compound 3, half-maximal effective concentration: 608 nM
Beside the measured number, compound 3's estimate is 1.0-fold (0.01 log units) below it; low and high end bracket the measured number.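

In this assay, among the compounds shown here, replacing 4-carboxy-3-chlorophenyl with 4-carboxy-2-methylphenyl on an oxygen on a saturated carbon gives a 1.2-fold higher number from compound 2 to compound 3 (0.08 log units; within the scatter), the first measured step at this position. Compound 2 and compound 3 therefore cannot be told apart on this read-out, showing that this position accepts either group without a change beyond the scatter. Nothing measured here accounts for this outcome.

The pair does not separate the exchange of the chlorine for the methyl from the change in the group's place on the ring, and compound 1, with its methyl ester, offers no number for comparison. On these data alone, how a tetrazole or a primary amide would fare in place of the carboxylic acid also remains open, as does the effect of a longer chain at the saturated carbon.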